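The source may hold more compounds than are shown below. What is called first, only, known or untested is meant among the compounds shown, and "the series" means these compounds.

Measured so far in a functional assay on HCT-116 cells (Homo sapiens) for inhibition, read by MTT assay, with a stated time of 2 days, tested at 100 uM; on this read-out higher numbers stand for more inhibition of growth at the one concentration tested and lower numbers for less inhibition of growth:
compound 1 `CNC(=O)c1cc(Oc2ccc3nc(NC(=O)c4ccc(Cl)cc4)sc3c2)ccn1` gives 80.5%;
compound 2 `CNC(=O)c1cc(Oc2ccc3nc(NC(=O)Nc4ccc(N5CCN(C)CC5)cc4)sc3c2)ccn1` gives 95%;
compound 3 `CNC(=O)c1cc(Oc2ccc3nc(NC(=O)Nc4ccc(C5CCN(C(C)C)CC5)cc4)sc3c2)ccn1` gives 95.5%.

Compound 1 stands lowest of these three numbers, with compound 2 nearest above it and compound 3 furthest, both gaps beyond the scatter. Compound 4 `CNC(=O)c1cc(Oc2ccc3nc(NC(=O)c4cc(Cl)cc(Cl)c4)sc3c2)ccn1` differs from compound 1 in one place: 3,5-dichlorophenyl in place of 4-chlorophenyl on a carbonyl carbon. Going by the values given here, the only measured step, a number 0.5 percentage points higher from compound 2 to compound 3 (within the scatter), changes a group on a different part of the molecule and lies within the scatter, so no measured step bears on a change at the chlorophenyl. No expectation of a step beyond the scatter can be drawn. The estimated step is a number 0.5 percentage points lower from compound 1 to compound 4 (within the scatter). Compound 4 is expected to give 80% in this assay, with a range from 60% to 95%.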

Compound 4, percent growth inhibition at one concentration: 15.8%
Compound 4: middle estimate off by 64.2 percentage points, on the high side, outside the stated range (below it).
By their numbers in this assay, from the lowest: compound 4; then compound 1; then compounds 2 and 3 (each within the scatter of the next).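

In this assay, replacing 4-chlorophenyl with 3,5-dichlorophenyl on the carbonyl carbon gives a large change (a number 64.7 percentage points lower from compound 1 to compound 4 (beyond the scatter)). The earlier compounds shown here did not test this site, and this pair shows that a single change to the chlorine pattern here can remove most of the growth inhibition seen at the one concentration tested. Nothing available here accounts for the drop.

Compounds 1 and 4 alone cannot separate the effect of the added chlorine from that of the changed chlorine pattern. Going by these compounds, whether plain phenyl, or a methoxy or amino group on this ring, would keep the inhibition remains open.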